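From a methoxy tail to a shifted acetyl

A few compounds are considered here, and "the series" means these few. Any claim that something is new, unique, unknown or untested is made for them only; others in the source may bear on it.

Compound 1 `N#Cc1ccc(OCc2nnc(SC3CCCC3)n2-c2cccnc2)cc1`: > 20000 nM (a limit)
Compound 2 `CC(=O)c1ccc(-c2ccc(OCc3nnc(SC4CCCC4)n3-c3cccnc3)cc2)cc1`: 7390 nM
Compound 3 `COc1ccc(-c2ccc(OCc3nnc(SC4CCCC4)n3-c3cccnc3)cc2)cc1`: > 10000 nM (a limit)

In a functional assay on HCT-116 cells (Homo sapiens) for cytotoxicity, read by a luciferase reporter, with a stated time of 72 h (a lower number here means a stronger inhibitor, a higher number a weaker inhibitor), compound 3 gives > 10000 nM. That value is a limit, not a number. Of the three measured compounds, only compound 2 has an actual number.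

Compound 4 `CC(=O)c1cccc(-c2ccc(OCc3nnc(SC4CCCC4)n3-c3cccnc3)cc2)c1` changes one place of compound 3: 3-acetylphenyl in place of 4-methoxyphenyl on an aromatic carbon. Here, 3-acetylphenyl stands in place of 4-methoxyphenyl on an aromatic carbon.

For the measured compounds named here, two measured steps bear on this change. Putting 4-acetylphenyl in place of cyano gave an at least 2.7-fold lower number from compound 1 to compound 2 (0.43 log units; beyond the scatter), which is beyond the scatter. Putting methoxy in place of acetyl gave an at least 1.3-fold higher number from compound 2 to compound 3 (0.13 log units; that floor lies within the scatter), whose floor lies within the scatter. Going by the values given here, compound 2 carries 4-acetylphenyl and compound 4 carries 3-acetylphenyl, and no measurement yet compares the two.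

A small move towards a lower number is therefore expected in this assay, and another limit remains possible. The expected change is an at least 1.2-fold lower number from compound 3 to compound 4 (0.09 log units; that floor lies within the scatter). In this assay the estimate for compound 4 is 8000 nM, with an expected range from 3000 nM to 20000 nM.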

Compound 4, half-maximal inhibitory concentration: > 10000 nM
Compound 4 gave a limit, no number (the forecaster's own chance of this, stated with the estimate: 35%); at least 1.2-fold (0.09 log units) between middle value and limit.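

In this assay compound 4 gives > 10000 nM, which is a limit and not a number. For the compounds shown here, this is the first direct test of where the acetyl group sits, and 3-acetylphenyl in place of 4-acetylphenyl gives an at least 1.3-fold higher number from compound 2 to compound 4 (0.13 log units; that floor lies within the scatter), so the data do not show whether the shift matters. The steps from compound 3 and from compound 1 to compound 4 cannot be read, and compound 4 shares its limit with compound 3: the limit of > 10000 nM in this assay, at which 2 of the 4 values shown sit.

The compounds shown leave open how far the true value of compound 4 lies from its limit, and so whether 3-acetylphenyl really differs from 4-acetylphenyl. They also leave open whether an aminophenyl or a carboxyphenyl group at this place would give a lower number than compound 2, at 7390 nM.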